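The compounds below may be only part of what the source reports. "The series", "measured", "known", "first", "only" and "open" are said of these compounds alone.

Compound 1, `CC#CCn1c(N2CCC[C@@H](N)C2)nc2c1c(=O)n(Cc1ccccc1C(=O)O)c(=O)n2C`: in an ADME assay on isolated protein for inhibition of Dipeptidyl peptidase 9 (Homo sapiens), with stated times of 15 min, 60 s and 20 min (a lower number here means a stronger inhibitor, a higher number a weaker inhibitor), compound 1 gives > 100000 nM, which is a limit of the assay and not a number.
Compound 2, `CC#CCn1c(N2CCC[C@@H](N)C2)nc2c1c(=O)n(Cc1cccc(F)c1C(=O)O)c(=O)n2C`: in this assay compound 2 gives > 100000 nM, again a limit of the assay.

Among the measured compounds shown here, compound 2 therefore stands only at a limit in this assay, with no number of its own; the one further value shown, that of compound 1, is also a limit. For the measured compounds named here, the single measured step, a step that the two limits leave unreadable from compound 1 to compound 2, is unreadable because of the limit of > 100000 nM in this assay, at which 2 of the 2 values shown sit, so its size is unknown.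

Compound 3, `CC#CCn1c(N2CCC[C@@H](N)C2)nc2c1c(=O)n(Cc1ccc(Br)cc1C(=O)OCC)c(=O)n2C`, is not yet measured in this assay. It differs from compound 2 by 4-bromo-2-(ethoxycarbonyl)phenyl in place of 2-carboxy-3-fluorophenyl on a saturated chain carbon bound to an aromatic nitrogen. Going by the values given here, no measured step bears on this change: the only step recorded, from compound 1 to compound 2, sits between two limits and carries no size, and neither the ester nor the bromine appears in any measured pair. The step from compound 2 to compound 3 is thus expected to be an at least 1.4-fold lower number from compound 2 to compound 3 (0.15 log units; that floor lies within the scatter), as an estimate without a measured anchor. For compound 3 in this assay the expected value is 70000 nM, with a range from 15000 nM to 300000 nM, and a fair chance that only a limit is reported.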

Compound 3, half-maximal inhibitory concentration: > 100000 nM
Compound 3: a limit, no number; the forecaster's own chance of this, stated with the estimate: 55%; at least 1.4-fold (0.15 log units) between middle value and limit.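

Compound 3 joins compound 1 and compound 2 at a limit in this assay, so neither step to compound 3, from compound 2 or from compound 1, can be read, the reason being: the limit of > 100000 nM in this assay, at which 3 of the 3 values shown sit. Still open, from the compounds shown here alone, is whether 4-bromo-2-(ethoxycarbonyl)phenyl and 2-carboxy-3-fluorophenyl differ at all in this assay.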